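The source may hold more compounds than are shown below. What is called first, only, known or untested is meant among the compounds shown, and "the series" means these compounds.

Measured compounds in a functional assay on K562 cells (Homo sapiens) for inhibition, read by sulforhodamine B assay, with a stated time of 48 h, tested at 10 uM; a lower number here means less inhibition, a higher number more inhibition at the concentration tested (going by the name of the read-out):
compound 1 `COc1ccc(-c2cn3ccnc3c(-c3ccc4ncn(C5CCCCC5)c4c3)n2)cc1` gives 92%;
compound 2 `c1ccc2c(-c3cn4ccnc4c(-c4ccc5ncn(C6CCCCC6)c5c4)n3)cccc2c1` gives 30.9%;
compound 3 `Fc1ccc(-c2cn3ccnc3c(-c3ccc4ncn(C5CCCCC5)c4c3)n2)cc1` gives 24.7%.

Compound 3 has the lowest of the three numbers; compound 2 sits nearest, within the scatter, while compound 1 lies far above it. Compound 4 `c1cn2cc(-c3ccsc3)nc(-c3ccc4ncn(C5CCCCC5)c4c3)c2n1` differs from compound 3 by thiophen-3-yl in place of 4-fluorophenyl on an aromatic carbon. For the measured compounds named here, no measured step covers this exchange directly. The steps of a number 61.1 percentage points lower from compound 1 to compound 2 (beyond the scatter) and a number 67.3 percentage points lower from compound 1 to compound 3 (beyond the scatter) show that changing this group can move the read-out a great deal, whereas a number 6.2 percentage points lower from compound 2 to compound 3 (within the scatter) shows it can also leave it unchanged. Going by the values given here, with no closer precedent, the step of a number 10.3 percentage points higher from compound 3 to compound 4 (beyond the scatter) is expected to be modest and uncertain in direction. Compound 4 is therefore estimated at 35%, within 10% to 70%.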

Compound 4, a percentage reported as inhibition, at one concentration (the size of the read-out at that concentration, not a potency): 22%
The estimate for compound 4 lay 13 percentage points above the measured number, within the range that was stated.
By their numbers in this assay, from the lowest: compounds 4, 3 and 2 (each within the scatter of the next); then compound 1.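

In this assay, thiophen-3-yl reads like 4-fluorophenyl (a number 2.7 percentage points lower from compound 3 to compound 4 (within the scatter)) and like naphthalen-1-yl (a number 8.9 percentage points lower from compound 2 to compound 4 (within the scatter)), so a five-membered aromatic ring with a sulfur atom fits the same low band as the two carbon-only aryl groups at this position. Only 4-methoxyphenyl stands apart (a number 70 percentage points lower from compound 1 to compound 4 (beyond the scatter)), which leaves compound 1 as the single exception among the four. Nothing measured here explains this result. From the compounds shown here alone, it remains open whether the high number depends on the methoxy group itself, and whether a hydroxy, ethoxy or dimethylamino group in its place would keep it.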